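A few compounds are considered here, and "the series" means these few. Any claim that something is new, unique, unknown or untested is made for them only; others in the source may bear on it.

Measured in an ADME assay on S9 fraction from liver (Rattus norvegicus) for metabolic stability, read by LC-MS, using NADPH, with a stated time of 30 min; on this read-out lower numbers stand for a less stable compound and higher numbers for a more stable compound:

Compound 1 `CCCCCCCCc1ccc(OCC(=O)Cn2ncnn2)cc1`: < 5%, a limit.
Compound 2 `CCCCCCCCc1ccc(OCC(=O)Cn2nnc(-c3cccc(S(=O)(=O)N(C)C)c3)n2)cc1`: 9%.
Compound 3 `CCCCCCCCc1ccc(OCC(=O)Cn2nnc(Cc3ccccc3)n2)cc1`: < 5%, a limit.

Compound 3 therefore has no number, only a limit, and it stands at the limit of < 5% in this assay, at which 2 of the 3 values shown sit. The next compound to be measured is compound 4 `CCCCCCCCc1ccc(OCC(=O)Cn2nnc(CCC(=O)O)n2)cc1`. The change is carboxymethyl in place of phenyl on a saturated chain carbon bound to an aromatic carbon, or, cut one bond further out, benzyl to 2-carboxyethyl.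

For the measured compounds named here, no measured step makes this exact change, but three alter the same substituent: a number at least 4 percentage points higher from compound 1 to compound 2 (that floor lies within the scatter), a number at least 4 percentage points lower from compound 2 to compound 3 (that floor lies within the scatter) and a step that the two limits leave unreadable from compound 1 to compound 3. None of them is shown to exceed the scatter, so no step beyond the scatter is expected in this assay, in either direction. The expected step is a number at least 1 percentage points higher from compound 3 to compound 4 (that floor lies within the scatter). The estimated value for compound 4 is 6%, with an expected range from 2% to 18%.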

Compound 4, percent of the compound remaining: < 5%
Compound 4: a limit, no number (the forecaster's own chance of this, stated with the estimate: 55%); middle value at least 1 percentage points away from the limit.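

In this assay compound 4 gives < 5%, which is a limit and not a number. For the compounds shown here, the steps to compound 4 from compound 1 and from compound 3 cannot be read, and the one readable step is a number at least 4 percentage points lower from compound 2 to compound 4 (that floor lies within the scatter). A carboxylic acid at the end of this chain therefore does not bring the compound off the limit, and compound 4 joins compound 1 and compound 3: the limit of < 5% in this assay, at which 3 of the 4 values shown sit.

How far compound 1, compound 3 and compound 4 lie apart under that limit stays open, as does whether 3-(dimethylsulfamoyl)phenyl truly stands apart from them, since its step is not shown to exceed the scatter. Also open, from the compounds shown here alone, is whether an amine, a primary amide or a longer chain at this position would give a readable number.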